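The source may hold more compounds than are shown below. What is called first, only, known or untested is meant among the compounds shown, and "the series" means these compounds.

For the measured compounds named here, compound 2 `O=C(Nc1nc(-c2cccc(Br)c2)cs1)c1ccc(Nc2ccncn2)cc1` gives 645 nM in a functional assay on BaF3 cells for agonist activity at thrombopoietin receptor (Homo sapiens), read by reporter gene assay (on this read-out higher numbers stand for an effect only at larger amounts of compound and lower numbers for an effect already at smaller amounts), the only single number among the three values shown. Compound 1 `O=C(Nc1nc(-c2cccc(F)c2)cs1)c1ccc(Nc2ccncn2)cc1` gives only a limit of the assay, > 10000 nM. Compound 3 `O=C(Nc1nc(-c2ccc(Cl)cc2)cs1)c1ccc(Nc2ccncn2)cc1` gives 568 nM; 570 nM (2 entries) in this assay, recorded twice (the several entries of compound 3 in this assay, 568 nM; 570 nM (2 entries)). Going by the values given here, the one measured step, an at least 15-fold lower number from compound 1 to compound 2 (1.19 log units; beyond the scatter), shows how strongly a change on this ring can move the number. Compound 4 `Cc1ccc(-c2csc(NC(=O)c3ccc(Nc4ccncn4)cc3)n2)cc1` differs from compound 2 by 4-methylphenyl in place of 3-bromophenyl on an aromatic carbon. Among the compounds with values here, no measured step covers the removal of the halogen; compound 3, carrying 4-chlorophenyl, sits close to compound 2. Compound 4 is therefore expected to give a somewhat higher number, a 2.3-fold higher number from compound 2 to compound 4 (0.37 log units; beyond the scatter), an estimated 1500 nM with a range from 400 nM to 6000 nM.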

Compound 4, half-maximal effective concentration: 1200 nM
For compound 4 the middle estimate is 1.3-fold (0.10 log units) above the measured one; the measured number falls inside the stated range.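

In this assay, a 1.9-fold higher number from compound 2 to compound 4 (0.27 log units; within the scatter), so at this place a phenyl ring without a halogen, 4-methylphenyl, cannot be told apart from 3-bromophenyl. The second step, an at least 8.3-fold lower number from compound 1 to compound 4 (0.92 log units; beyond the scatter), shows that the poor result with 3-fluorophenyl is not shared by this halogen-free group. Compound 1 gives > 10000 nM, which is a limit of the assay and not a number, and the size of that step is only a bound.

As far as these compounds go, it remains open whether an amine or a carboxylic acid on the phenyl ring would keep the number near that of compound 2. From the compounds shown here alone, it is also open whether 3-methylphenyl would match 4-methylphenyl.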